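A Methyl Group Added to the Chain of Compound 3

The source may hold more compounds than are shown below. What is called first, only, known or untested is meant among the compounds shown, and "the series" means these compounds.

Three compounds share one core and differ only in the group carried on a chain carbon bound to an amide-type nitrogen: compound 1 `CCCCCCNC(=O)c1[nH]cnc1C(=O)Nc1ccc(Cl)c(Cl)c1`, compound 2 `Cc1ccc(CNC(=O)c2[nH]cnc2C(=O)Nc2ccc(Cl)c(Cl)c2)cc1` and compound 3 `CC(C)(C)OC(=O)CNC(=O)c1[nH]cnc1C(=O)Nc1ccc(Cl)c(Cl)c1`. In a functional assay on HL-60 cells (Homo sapiens), with a stated time of 2 days (on this read-out lower numbers stand for stronger inhibition and higher numbers for weaker inhibition), compound 1 gives 14600 nM, compound 2 gives 21400 nM and compound 3 gives 49800 nM. Compound 3 stands highest of the three: there is a 3.4-fold higher number from compound 1 to compound 3 (0.53 log units; beyond the scatter) and a 2.3-fold higher number from compound 2 to compound 3 (0.37 log units; beyond the scatter), while a 1.5-fold higher number from compound 1 to compound 2 (0.17 log units; within the scatter). Compound 4 `C[C@@H](NC(=O)c1[nH]cnc1C(=O)Nc1ccc(Cl)c(Cl)c1)C(=O)OC(C)(C)C` keeps the tert-butoxycarbonyl group of compound 3 and adds one atom: methyl in place of hydrogen on a saturated chain carbon bound to an amide-type nitrogen and a carbonyl carbon. Among the compounds with values here, none of the measured steps bears directly on this change, since each of them exchanges the whole group on that carbon rather than a single hydrogen for a methyl. Without a guiding step, the expectation for this assay is no change beyond the scatter, a 1.0-fold higher number from compound 3 to compound 4 (0.00 log units; within the scatter). Compound 4 is therefore estimated at 50000 nM, with a range from 20000 nM to 125000 nM.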

Compound 4, half-maximal inhibitory concentration: 4600 nM
Compound 4: middle estimate off by 11-fold (1.04 log units), on the high side; measured number outside the range, below it.
By their numbers in this assay, from the lowest: compound 4; then compounds 1 and 2 (each within the scatter of the next); then compound 3.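

In this assay, within the data shown here, adding one methyl to the saturated chain carbon bound to an amide-type nitrogen and a carbonyl carbon gives an 11-fold lower number from compound 3 to compound 4 (1.03 log units; beyond the scatter), a larger step than any exchange of the whole group among the earlier compounds. The order also turns over, with a 4.7-fold lower number from compound 2 to compound 4 (0.67 log units; beyond the scatter) and a 3.2-fold lower number from compound 1 to compound 4 (0.50 log units; beyond the scatter), so the tert-butoxycarbonyl group does not by itself set the high number of compound 3, and this small change matters more here than replacing the entire group. Nothing measured here explains the gain.

From the compounds shown here alone, whether a longer chain such as ethyl or isopropyl in place of the methyl would hold or extend the gain stays open. So does whether the methyl would still give a low number with a carboxylic acid in place of the tert-butoxycarbonyl group.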